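Aryl swap from dichlorophenyl to fluoro-methylphenyl in the series

The source may report more compounds than this note shows. Statements on the series, on what has been measured and on what is new or still open speak of the compounds shown alone.

For the measured compounds named here, compound 3 `CCCS(=O)(=O)Nc1ccc(F)c(C(=O)c2n[nH]c3ncc(-c4ccc(Cl)c(Cl)c4)cc23)c1F` gives 45% in an assay for binding affinity to dual specificity mitogen-activated protein kinase kinase 4 (Homo sapiens), read by KINOMEscan, tested at 100 nM (on this read-out higher numbers stand for a weaker effect at the one concentration tested and lower numbers for a stronger effect), and stands highest of the three numbers measured so far. Compound 1 `CCCS(=O)(=O)Nc1ccc(F)c(C(=O)c2n[nH]c3ncc(-c4ccccc4C)cc23)c1F` gives 7% in this assay, and compound 2 `CCCS(=O)(=O)Nc1ccc(F)c(C(=O)c2n[nH]c3ncc(-c4ccccc4O)cc23)c1F` gives 9%; these two lie within the scatter of each other, a number 2 percentage points higher from compound 1 to compound 2 (within the scatter). Compound 3 is set apart from both: a number 38 percentage points higher from compound 1 to compound 3 (beyond the scatter), and a number 36 percentage points higher from compound 2 to compound 3 (beyond the scatter).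

Compound 4 `CCCS(=O)(=O)Nc1ccc(F)c(C(=O)c2n[nH]c3ncc(-c4ccc(F)cc4C)cc23)c1F` is the next member. 4-fluoro-2-methylphenyl in place of 3,4-dichlorophenyl on an aromatic carbon The change brings back the methyl group that compound 1 carries and adds a fluorine, while both chlorines leave. Going by the values given here, the steps that bear on this are the two large ones from compound 1 and compound 2 to compound 3, each beyond the scatter; read in reverse they point to the number falling again once the 3,4-dichlorophenyl is gone. Among the compounds with values here, no measured step shows what the added fluorine does on its own, so the expectation rests on the shared methyl with compound 1 and its value 7%.

Compound 4 is therefore expected to give about 10% in this assay, within a range of 3% to 25%. The expected step is a number 35 percentage points lower from compound 3 to compound 4 (beyond the scatter), downward and beyond the scatter.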

Compound 4, a percentage reported as activity, at one concentration (the size of the read-out at that concentration, not a potency): 14%
For compound 4 the middle estimate is 4 percentage points below the measured one; the measured number falls inside the stated range.
By their numbers in this assay, from the lowest: compounds 1, 2 and 4 (each within the scatter of the next); then compound 3.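

In this assay, the read-out at this position returns from the level of compound 3 to the range of the other compounds (a number 31 percentage points lower from compound 3 to compound 4 (beyond the scatter)), so the large gap seen earlier is not fixed to the core and depends on the aryl group carried there. Fluoro added to the 2-methylphenyl ring is tolerated without a resolved change (a number 7 percentage points higher from compound 1 to compound 4 (within the scatter)), and 4-fluoro-2-methylphenyl also stays level with 2-hydroxyphenyl (a number 5 percentage points higher from compound 2 to compound 4 (within the scatter)), which leaves compound 3, with its 3,4-dichlorophenyl, as the only one of the four set apart. Nothing at hand explains why this group differs from the other three.

Still open, from the compounds shown here alone, is whether the gap follows from the two chlorines themselves or from the loss of the methyl or hydroxy group, a question that 3-chlorophenyl, 4-chlorophenyl and 3,4-dichloro-2-methylphenyl groups would help to separate. Also open, going by these compounds, is how far this tolerance extends to a 2-aminophenyl group, a 2-methoxyphenyl group or a pyridine ring at the same carbon.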